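A few compounds are considered here, and "the series" means these few. Any claim that something is new, unique, unknown or untested is made for them only; others in the source may bear on it.

Working notes on the series. Three compounds share one core and differ only in the aryl group on the carbon with a double bond to nitrogen. Compound 1 `COc1ccc(C2C(C#N)=C(/N=C/c3ccccc3Cl)Oc3nc(Nc4ccc(S(N)(=O)=O)cc4)sc32)cc1` carries a 2-chlorophenyl there and in a functional assay on MCF7 cells (Homo sapiens) for cytotoxicity, read by sulforhodamine B assay, with a stated time of 48 h (on this read-out higher numbers stand for weaker inhibition and lower numbers for stronger inhibition), compound 1 gives 10300 nM. Compound 2 `COc1ccc(C2C(C#N)=C(/N=C/c3cccc(Br)c3)Oc3nc(Nc4ccc(S(N)(=O)=O)cc4)sc32)cc1` carries a 3-bromophenyl, and in this assay compound 2 gives 9390 nM; the step of a 1.1-fold lower number from compound 1 to compound 2 (0.04 log units; within the scatter) separates them. Compound 3 `COc1ccc(C2C(C#N)=C(/N=C/c3ccc(F)cc3)Oc3nc(Nc4ccc(S(N)(=O)=O)cc4)sc32)cc1` carries a 4-fluorophenyl, and in this assay compound 3 gives 28900 nM, the highest number of the three: the steps of a 2.8-fold higher number from compound 1 to compound 3 (0.45 log units; beyond the scatter) and a 3.1-fold higher number from compound 2 to compound 3 (0.49 log units; beyond the scatter) both run upward to it.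

Compound 4 `COc1ccc(C2C(C#N)=C(/N=C/c3ccc(Cl)cc3Cl)Oc3nc(Nc4ccc(S(N)(=O)=O)cc4)sc32)cc1` is not yet measured. The change is 2,4-dichlorophenyl in place of 4-fluorophenyl on a carbon with a double bond to nitrogen. Bearing on it are the two steps into compound 3 from compound 1 and compound 2; read backwards, both would move the number down by a modest amount, and compound 1 already holds a 2-chlorophenyl at the same place. The expectation is therefore a modest lowering, a 6.4-fold lower number from compound 3 to compound 4 (0.81 log units; beyond the scatter), in this assay. Compound 4 is estimated at 4500 nM, with a range from 1500 nM to 13000 nM.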

Compound 4, half-maximal inhibitory concentration: 23500 nM
For compound 4 the middle estimate is 5.2-fold (0.72 log units) below the measured one; measured number above the stated range.
By their numbers in this assay, from the lowest: compounds 2 and 1 (each within the scatter of the next); then compounds 4 and 3 (each within the scatter of the next).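

In this assay the 2-chlorophenyl group does not set the number on its own: chloro in place of hydrogen on an aromatic carbon gives a 2.3-fold higher number from compound 1 to compound 4 (0.36 log units; beyond the scatter) and so moves the 2,4-dichlorophenyl group away from compound 1. The same group also stands apart from the 3-bromophenyl group, with a 2.5-fold higher number from compound 2 to compound 4 (0.40 log units; beyond the scatter) on record, whereas a 1.2-fold lower number from compound 3 to compound 4 (0.09 log units; within the scatter) leaves it level with the 4-fluorophenyl group, so the four compounds now fall into a lower pair, compounds 1 and 2, and a higher pair, compounds 3 and 4. No independent data at hand explain this split.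

From the compounds shown here alone, all four groups on this carbon are halogen-bearing phenyl rings, so how a phenyl ring carrying an amine or a carboxylic acid would read stays open. Also open, going by these compounds, is whether a 4-chlorophenyl group would fall with the higher pair.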